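The source may hold more compounds than are shown below. What is called first, only, known or untested is meant among the compounds shown, and "the series" means these compounds.

Measured compounds:
Compound 1, `CN1CCN(CCNCc2cn(-c3ccc(F)cc3F)nc2Cc2ccccc2)CC1`, gives > 20000 nM.
Compound 2, `CN1CCN(CCNCc2cn(-c3ccc(F)cc3F)nc2-c2cccc(N(C)C)c2)CC1`, gives > 20000 nM.
Compound 3, `CN1CCN(CCNCc2cn(-c3ccc(F)cc3F)nc2-c2ccc(S(=O)(=O)N(C)C)cc2)CC1`, gives > 20000 nM.
Each of these three values is a limit of the assay, not a number.

In an ADME assay on Huh-7 cells (Homo sapiens) for cytotoxicity (a higher number here means that more compound is tolerated, a lower number that less compound is tolerated), compound 3 stands at the limit of > 20000 nM in this assay, at which 3 of the 3 values shown sit, so its true value is not known beyond that limit. Compound 4 is `CN1CCN(CCNCc2cn(-c3ccc(F)cc3F)nc2-c2ccccc2)CC1`, and the change from compound 3 is hydrogen in place of dimethylsulfamoyl on an aromatic carbon. For the measured compounds named here, two measured steps touch the 4-(dimethylsulfamoyl)phenyl group that leaves: a step that the two limits leave unreadable from compound 1 to compound 3 and a step that the two limits leave unreadable from compound 2 to compound 3. Both are unreadable, since every value sits at the same limit, so they give no size and no direction. Nothing here suggests a step in this assay beyond the scatter, and the expectation is that compound 4 again reaches the limit. The step this estimate means, a step that the limit leaves unreadable from compound 3 to compound 4, is expected to be small. Compound 4 is therefore estimated at 30000 nM, with a range from 12000 nM to 80000 nM.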

Compound 4, half-maximal cytotoxic concentration: > 20000 nM
Compound 4: only a limit was reported (the forecaster's own chance of this, stated with the estimate: 75%); the middle value does not contradict the limit.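

Compound 4, like compounds 1, 2 and 3, reaches a limit and not a number in this assay, so no step among these four compounds can be read: the limit of > 20000 nM in this assay, at which 4 of the 4 values shown sit.

The compounds shown leave open at what concentration any of them harms these cells, and whether their differing groups change it.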